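Carbonyl returns to the side-chain oxygen of compound 2

A few compounds are considered here, and "the series" means these few. Any claim that something is new, unique, unknown or untested is made for them only; others in the source may bear on it.

Among the measured compounds shown here, in a functional assay on DU-145 cells (Homo sapiens) for cytotoxicity, read by MTT assay (on this read-out lower numbers stand for stronger inhibition and higher numbers for weaker inhibition), compound 2 (`CC(C)=CC[C@@H](OC[C@@H](C)O)C1=CC(=O)c2c(O)ccc(O)c2C1=O`) gives 14300 nM, the only true number so far. Compound 1 (`CC(C)=CC[C@@H](OC(=O)c1ccco1)C1=CC(=O)c2c(O)ccc(O)c2C1=O`) reads > 100000 nM, which is a limit of the assay. Compound 3 (`CCCCC(O)CC(=O)O[C@H](CC=C(C)C)C1=CC(=O)c2c(O)ccc(O)c2C1=O`) carries (2-hydroxyhexyl)carbonyl in place of 2-hydroxypropyl on an oxygen on a saturated carbon. For the measured compounds named here, one measured step bears on this change: an at least 6.9-fold lower number from compound 1 to compound 2 (0.84 log units; beyond the scatter), where (furan-2-yl)carbonyl left that oxygen. A carbonyl on that oxygen therefore points towards weaker inhibition in this assay, and the expected step is a 1.5-fold higher number from compound 2 to compound 3 (0.19 log units; within the scatter), smaller than that one. For compound 3 the estimate is 22000 nM, with an expected range of 6000 nM to 80000 nM.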

Compound 3, half-maximal inhibitory concentration: 45300 nM
Compound 3: the middle estimate sits 2.1-fold (0.31 log units) below what was measured, within the range that was stated.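

Among the compounds shown here, compound 3 gives the first pair of true numbers at this oxygen, and the carbonyl-bearing group reads weaker than the ether: a 3.2-fold higher number from compound 2 to compound 3 (0.50 log units; beyond the scatter). The group on the carbonyl carbon also matters, with 2-hydroxyhexyl in place of furan-2-yl giving an at least 2.2-fold lower number from compound 1 to compound 3 (0.34 log units; beyond the scatter). Compound 1 stands at a limit of the assay, not at a number: the limit of > 100000 nM in this assay, at which 1 of the 3 values shown sits.

Carbonyl and chain change together in the step to compound 3, so the share of each stays open. A 2-hydroxyhexyl ether or an acetyl group on this oxygen would separate them.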